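The compounds below may be only part of what the source reports. "The series", "measured", "known", "first", "only" and "open" are said of these compounds alone.

Compound 1 `O=C(C1=C(OC2CCCCC2)C(=O)N(CCCn2ccnc2)C1c1ccc(Br)cc1)c1ccccc1` carries a cyclohexyloxy group on a double-bonded ring carbon of the shared core. In a functional assay on NCI-H1299 cells (Homo sapiens) for antiproliferative activity, read by MTT assay, with a stated time of 72 h (a higher number here means a weaker inhibitor, a lower number a stronger inhibitor), compound 1 gives 19900 nM. Compound 2 `O=C(C1=C(Nc2ccc(F)cc2)C(=O)N(CCCn2ccnc2)C1c1ccc(Br)cc1)c1ccccc1` carries (4-fluorophenyl)amino in that place, and in this assay compound 2 gives 25400 nM. The step of a 1.3-fold higher number from compound 1 to compound 2 (0.11 log units; within the scatter) lies within the scatter, so among the two numbers measured, compound 2 cannot be told apart from compound 1; both sit in the same weak range.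

Compound 3 `O=C(C1=C(Nc2ccc(Br)cc2)C(=O)N(CCCn2ccnc2)C1c1ccc(Br)cc1)c1ccccc1` differs from compound 2 by bromo in place of fluoro on an aromatic carbon. Among the measured compounds shown here, no measured step swaps one halogen for another on this aromatic ring. For the measured compounds named here, the single step that exists, a 1.3-fold higher number from compound 1 to compound 2 (0.11 log units; within the scatter), concerns a different exchange at a different place and itself stayed within the scatter, so it gives no direction for the present change. Going by the values given here, compound 2 is therefore the only anchor for compound 3.

Compound 3 is expected to give a number close to that of compound 2, with the step of a 1.1-fold lower number from compound 2 to compound 3 (0.02 log units; within the scatter) not beyond the scatter. The estimate for compound 3 in this assay is 24000 nM, within a range from 9000 nM to 65000 nM.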

Compound 3, half-maximal inhibitory concentration: 19300 nM
For compound 3 the middle estimate is 1.2-fold (0.09 log units) above the measured one; the range from low to high includes it.
By their numbers in this assay, from the lowest: compounds 3, 1 and 2 (each within the scatter of the next).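

Swapping fluoro for bromo on the aromatic ring, para to a large group, is the first halogen exchange at this place, and in this assay it gives a 1.3-fold lower number from compound 2 to compound 3 (0.12 log units; within the scatter). Fluoro and bromo therefore cannot be told apart here, which adds a second kind of change to the earlier exchange on the double-bonded ring carbon. That carbon gives the same picture with the new group, since (4-bromophenyl)amino in place of cyclohexyloxy gives a 1.0-fold lower number from compound 1 to compound 3 (0.01 log units; within the scatter), so all three compounds remain in one weak range and none can be ranked above another. No independent measurement is available to explain why these numbers stay together.

Still open, from the compounds shown here alone, is whether a different kind of group on the aromatic ring, such as an amine or a carboxylic acid, would carry the number beyond the scatter. Going by these compounds, the other parts of the shared core are the same in all three compounds, so the effect of a shorter or longer chain at those places on activity in this assay also remains unknown.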